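Swapping the ester's aromatic group for a two-ring imide

The source may hold more compounds than are shown below. What is called first, only, known or untested is meant among the compounds shown, and "the series" means these compounds.

Of the compounds shown here, three sharing one core have been measured in an assay on isolated protein for binding affinity to Type-2 angiotensin II receptor (Homo sapiens); on this read-out higher numbers stand for weaker inhibition and lower numbers for stronger inhibition. Compound 1 `CCCCCCCOC(=O)NS(=O)(=O)c1ccccc1-c1ccc(Cn2c(CCC)nc(CC)c2C(=O)OCc2ccccc2OC)c(F)c1` gives 10 nM. Compound 2 `CCCc1nc(CC)c(C(=O)OCc2ccccc2Sc2ccccc2)n1Cc1ccc(-c2ccccc2S(=O)(=O)NC(=O)OCCC(C)C)cc1F` gives 2 nM. Compound 3 `CCCc1nc(CC)c(C(=O)OCc2ccccc2OC)n1Cc1ccc(-c2ccccc2S(=O)(=O)NC(=O)OCCC(C)C)cc1F` gives 1 nM, the lowest number of the three; its step to compound 2 is within the scatter, while its step to compound 1 is beyond it, as a 10-fold lower number from compound 1 to compound 3 (1.00 log units; beyond the scatter) shows.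

Compound 4 `CCCc1nc(CC)c(C(=O)OCCN2C(=O)c3ccccc3C2=O)n1Cc1ccc(-c2ccccc2S(=O)(=O)NC(=O)OCCC(C)C)cc1F` differs from compound 3 by a group of 12 heavy atoms (9 carbon, 1 nitrogen, 2 oxygen; one five-membered non-aromatic ring with 1 hetero atom, one six-membered aromatic ring of carbon only) in place of a group of 8 heavy atoms (7 carbon, 1 oxygen; one six-membered aromatic ring of carbon only), on a saturated chain carbon bound to an oxygen next to a carbonyl group. For the measured compounds named here, the only measured step at the same place is a 2.0-fold lower number from compound 2 to compound 3 (0.30 log units; within the scatter), where phenylsulfanyl against methoxy on the aromatic carbon made no difference beyond the scatter. The change from compound 3 to compound 4 is larger, as the whole 2-methoxyphenyl group leaves and a two-ring group of 12 heavy atoms enters, so a step beyond the scatter in this assay cannot be ruled out, but nothing measured points one way. The expected step is therefore a small one, a 3.0-fold higher number from compound 3 to compound 4 (0.48 log units; beyond the scatter), if any. Compound 4 is expected to give about 3 nM in this assay, within a range of 1 nM to 12 nM.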

Compound 4, half-maximal inhibitory concentration: 7 nM
Compound 4: the middle estimate sits 2.3-fold (0.37 log units) below what was measured; the range from low to high includes it.
By their numbers in this assay, from the lowest: compounds 3 and 2 (each within the scatter of the next); then compounds 4 and 1 (each within the scatter of the next).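

At this position, on a saturated chain carbon bound to an oxygen next to a carbonyl group, replacing the 2-methoxyphenyl group with the two-ring imide gives a 7.0-fold higher number from compound 3 to compound 4 (0.85 log units; beyond the scatter) in this assay. This is a change beyond the scatter, unlike the earlier swap of phenylsulfanyl and methoxy on the aromatic carbon, a 2.0-fold lower number from compound 2 to compound 3 (0.30 log units; within the scatter), so the group here can shift the number measurably, although compound 4 still gives 7 nM with the 2-methoxyphenyl group gone. No measurement shown here explains this step.

The compounds shown leave open which part of the imide group matters: the five-membered ring, its two carbonyl groups or the fused benzene ring. They also leave open how a simple amine or a carboxylic acid would compare in the same place.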